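Sulfonyl aryl exchange in a quinoline-type series: compound 3

A few compounds are considered here, and "the series" means these few. Any claim that something is new, unique, unknown or untested is made for them only; others in the source may bear on it.

The series is followed in an assay on isolated protein for displacement of a labelled ligand from metabotropic glutamate receptor 5 (Homo sapiens), with a stated time of 60 min, tested at 1 uM; on this read-out higher numbers stand for more inhibition at the one concentration tested (going by the name of the read-out) and lower numbers for less inhibition. Among the measured compounds shown here, compound 1 `COc1ccc(S(=O)(=O)c2cnc3ccc(OC)cc3c2N2CCC(C)CC2)cc1` gives 41% and is the lower of the two numbers measured so far. For the measured compounds named here, compound 2 `COc1ccc(S(=O)(=O)c2cnc3ccc(F)cc3c2N2CCC(C)CC2)cc1` gives 85% in this assay, and the only measured step, a number 44 percentage points higher from compound 1 to compound 2 (beyond the scatter), comes from fluoro in place of methoxy on an aromatic carbon of the shared core.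

Compound 3 `COc1ccc2ncc(S(=O)(=O)c3cccc(C#N)c3)c(N3CCC(C)CC3)c2c1` differs from compound 1 at another place: 3-cyanophenyl in place of 4-methoxyphenyl on a sulfonyl sulfur. Going by the values given here, no measured step concerns the aryl group on the sulfonyl sulfur, so the step from compound 1 to compound 2 does not bear on this change directly; it only shows that single changes can move the inhibition in this assay by a large amount. Among the compounds with values here, with no step at the sulfonyl aryl group, the direction for compound 3 cannot be read from the data. A modest rise is expected, a number 9 percentage points higher from compound 1 to compound 3 (within the scatter), with wide uncertainty. Compound 3 is therefore estimated at 50% in this assay, within the range 20% to 80%.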

Compound 3, a percentage reported as inhibition, at one concentration (the size of the read-out at that concentration, not a potency): 90%
The estimate for compound 3 lay 40 percentage points below the measured number; measured number outside the range, above it.
By their numbers in this assay, from the lowest: compound 1; then compounds 2 and 3 (each within the scatter of the next).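

The aryl group on the sulfonyl sulfur is now shown to be a second place where a single change matters in this assay: 3-cyanophenyl in place of 4-methoxyphenyl gives a number 49 percentage points higher from compound 1 to compound 3 (beyond the scatter) with the rest of compound 1 unchanged. This step is large even though the computed counts barely separate the two groups, each with 8 heavy atoms, one six-membered aromatic ring of carbon only, 1 hydrogen-bond acceptor and no net charge; the visible differences are the nitrile with its triple bond, the loss of the methoxy group and the different numbering of the substituent. Nothing available explains the rise or says which of these differences carries it.

Still open, as far as these compounds go, is whether a 3-methoxyphenyl, a 4-cyanophenyl or a plain phenyl on the sulfonyl sulfur would give a similar number in this assay, which would begin to separate the identity of the substituent from its place on the ring. Also open, from the compounds shown here alone, is how fluoro on the shared core and 3-cyanophenyl on the sulfonyl sulfur behave together in one compound, and how a carboxylic acid or a primary amide in place of the nitrile would read.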